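The source may hold more compounds than are shown below. What is called first, only, known or untested is meant among the compounds shown, and "the series" means these compounds.

Measured in a functional assay (muscle tissue) with Cavia porcellus as the target; a higher number here means that more compound is needed for the effect, a lower number that less compound is needed:
Compound 1 `COC(=O)C1=C(C)N=C(C)/C(=C(\O)OC)C1c1ccccc1C#N`: 15.9 nM
Compound 2 `CCc1ccccc1C1C(C(=O)OC)=C(C)N=C(C)/C1=C(\O)OC`: 6.46 nM
Compound 3 `C=Cc1ccccc1C1C(C(=O)OC)=C(C)N=C(C)/C1=C(\O)OC`: 4.47 nM

Compound 3 stands at the low end of this set: a 3.6-fold lower number from compound 1 to compound 3 (0.55 log units; beyond the scatter), while a 1.4-fold lower number from compound 2 to compound 3 (0.16 log units; within the scatter) stays within the scatter. Compound 4 `COC(=O)C1=C(C)N=C(C)/C(=C(\O)OC)C1c1c(Cl)cccc1Cl` has not yet been measured. It carries 2,6-dichlorophenyl in place of 2-vinylphenyl on a saturated ring carbon. The closest evidence comes from swaps of one group on the aromatic ring, and these were modest at most: a 2.5-fold lower number from compound 1 to compound 2 (0.39 log units; beyond the scatter). Among the compounds with values here, no measured compound carries chlorine, so no direction can be firmly expected, and no step beyond the scatter is expected in this assay. For compound 4 the estimated value is 4 nM, with an expected range of 1 nM to 16 nM. This estimate means an expected 1.1-fold lower number from compound 3 to compound 4 (0.05 log units; within the scatter).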

Compound 4, half-maximal effective concentration: 1.91 nM
Compound 4: middle estimate off by 2.1-fold (0.32 log units), on the high side; the measured number falls inside the stated range.
By their numbers in this assay, from the lowest: compound 4; then compounds 3 and 2 (each within the scatter of the next); then compound 1.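

Putting 2,6-dichlorophenyl in place of 2-vinylphenyl on the saturated ring carbon gives a change that clears the scatter in this assay (a 2.3-fold lower number from compound 3 to compound 4 (0.37 log units; beyond the scatter)), which the swap of ethyl for vinyl did not do. The same group also gives a lower number than 2-ethylphenyl (a 3.4-fold lower number from compound 2 to compound 4 (0.53 log units; beyond the scatter)) and 2-cyanophenyl (an 8.3-fold lower number from compound 1 to compound 4 (0.92 log units; beyond the scatter)), so compound 4 has the lowest number of the four. Nothing shown here explains this gain.

The compounds shown leave open whether a single chlorine would do the same. As far as these compounds go, how an amine or a carboxylic acid on this aromatic ring would behave also stays open.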